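Extending an Alkyl Chain by One Carbon: Compound 4

The source may report more compounds than this note shows. Statements on the series, on what has been measured and on what is new or still open speak of the compounds shown alone.

Of the compounds shown here, three of a shared core have been measured in a physicochemical assay for lipophilicity; a higher number here means a more lipophilic compound, a lower number a more polar compound. Compound 1 `CCOc1ccc2[nH]c(-c3ccccc3)c(C3=C(Br)C(=O)NC3=O)c2c1` gives 2.77. Compound 2 `CCCOc1ccc2[nH]c(-c3ccccc3)c(C3=C(Br)C(=O)NC3=O)c2c1` gives 3.16 in this assay, and compound 3 `CCCCCc1ccc2[nH]c(-c3ccccc3)c(C3=C(Br)C(=O)NC3=O)c2c1` gives 4.07 in this assay. Compound 3 stands highest of the three: a number 0.91 log units higher from compound 2 to compound 3 (beyond the scatter), and a number 1.30 log units higher from compound 1 to compound 3 (beyond the scatter). The core of compound 1 and the core of compound 3 differ in one place, (pentyl in place of ethoxy on an aromatic carbon).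

Compound 4 `CCCCCCc1ccc2[nH]c(-c3ccccc3)c(C3=C(Br)C(=O)NC3=O)c2c1` has not yet been measured in this assay. It differs from compound 3 by methyl in place of hydrogen on a saturated chain carbon, five bonds along the chain from an aromatic carbon. The same kind of change has been made once before among these compounds, from compound 1 to compound 2, where it reads (methyl in place of hydrogen on a saturated chain carbon, two bonds along the chain from an oxygen on an aromatic ring). The two places are not identical: in compound 2 the new methyl sits two bonds along the chain from an oxygen on an aromatic ring, while in compound 4 it sits five bonds along the chain from an aromatic carbon. That earlier step was a number 0.39 log units higher from compound 1 to compound 2 (beyond the scatter).

Going by the values given here, for compound 4 a step of a number 0.45 log units higher from compound 3 to compound 4 (beyond the scatter) in this assay is expected, which rests on the single earlier example because a number 0.39 log units higher from compound 1 to compound 2 (beyond the scatter). Compound 4 is therefore estimated at 4.52 in this assay, with a likely range from 4.2 to 4.85.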

Compound 4, partition coefficient: 4.39
Compound 4: the middle estimate sits 0.13 log units above what was measured, and the stated range covers the measured number.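

In this assay, methyl in place of hydrogen on a saturated chain carbon, five bonds along the chain from an aromatic carbon, gives a number 0.32 log units higher from compound 3 to compound 4 (beyond the scatter), and the same kind of change, two bonds along the chain from an oxygen on an aromatic ring, gave a number 0.39 log units higher from compound 1 to compound 2 (beyond the scatter), so in both of these settings the change moved the number the same way and each step is printed as modest. The larger steps, a number 1.23 log units higher from compound 2 to compound 4 (beyond the scatter) and a number 1.62 log units higher from compound 1 to compound 4 (beyond the scatter), replace an oxygen-linked chain with hexyl and so do not isolate the added methyl. Going by these compounds alone, these are only two examples, at different places on different chains, so they show that the change carried over between these two cores but not that it would carry over to any other core, and nothing available here accounts for the size of either step.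

The compounds shown leave open whether a longer chain than hexyl would keep giving a step of this kind. They also leave open how a chain bearing an amine or a carboxylic acid would stand on the shared core.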